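Working notes: from compound 2 toward a pyrazole variant

The compounds below may be only part of what the source reports. "The series", "measured", "known", "first", "only" and "open" are said of these compounds alone.

Measured so far:
compound 1, `CCCCS(=O)(=O)Nc1cc(-c2ccc3ncnc(Nc4ccc(OCCO)nc4)c3c2)cnc1OC`: in a functional assay on MCF7 cells (Homo sapiens) for antiproliferative activity, read by sulforhodamine B assay, with a stated time of 72 h (on this read-out lower numbers stand for stronger inhibition and higher numbers for weaker inhibition), compound 1 gives > 20000 nM, which is a limit of the assay and not a number.
compound 2, `COc1ncc(-c2ccc3ncnc(Nc4ccc(OCCO)c(F)c4)c3c2)cc1NS(=O)(=O)c1ccc(F)cc1F`: in this assay compound 2 gives 4820 nM.

Among the compounds with values here, compound 2 thus carries the only numeric value in this assay; the other entry is the limit of > 20000 nM in this assay, at which 1 of the 2 values shown sits. Within the data shown here, no pair of measured compounds differs in a single place, so no measured step is available to calibrate the change below.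

Compound 3, `COc1ncc(-c2ccc3ncnc(Nc4cnn(CCCO)c4)c3c2)cc1NS(=O)(=O)c1ccc(F)cc1F`, differs from compound 2 by 1-(3-hydroxypropyl)-1H-pyrazol-4-yl in place of 3-fluoro-4-(2-hydroxyethoxy)phenyl on a nitrogen on an aromatic ring. Without a measured step of this kind, the step expected in this assay from compound 2 to compound 3 is a 1.0-fold higher number from compound 2 to compound 3 (0.02 log units; within the scatter), that is, none beyond the scatter in either direction, with wide uncertainty. Compound 3 is therefore estimated at 5000 nM, within a range of 1500 nM to 20000 nM.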

Compound 3, half-maximal inhibitory concentration: 1310 nM
Estimate against measurement, compound 3: 3.8-fold (0.58 log units) above, outside the stated range (below it).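

Within the data shown here, at this nitrogen on an aromatic ring, the only measured step in this assay is a 3.7-fold lower number from compound 2 to compound 3 (0.57 log units; beyond the scatter) and it shows that 1-(3-hydroxypropyl)-1H-pyrazol-4-yl is accepted in place of 3-fluoro-4-(2-hydroxyethoxy)phenyl, with stronger inhibition. The exchange alters the ring, the fluorine and the chain in one move, so the step belongs to the whole group and cannot be divided among these parts. Nothing shown gives a cause for this step.

Still open, from the compounds shown here alone, is how much of the step follows the pyrazole ring itself and how much follows the 3-hydroxypropyl chain. Also open, going by these compounds, is whether a shorter 2-hydroxyethyl chain, or an amine or a carboxylic acid at the end of the chain, would hold the same level of inhibition on this pyrazole.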